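This account rests on a few compounds, and the source may have more. Where it says the series, first, only, none or still open, it means among the compounds named here.

Measured so far in an ADME assay on MT4 cells (Homo sapiens) for cytotoxicity, read by spectrophotometry, with a stated time of 5 days; a higher number here means that more compound is tolerated, a lower number that less compound is tolerated:
compound 1, `CCN(CC)CN1C(=O)/C(=N\NC(=S)NO)c2cc(Cl)ccc21`: 562000 nM
compound 2, `CCN(CC)CN1C(=O)/C(=N\NC(=S)NOC)c2cc(Cl)ccc21`: 454000 nM
compound 3, `O=C1/C(=N\NC(=S)NO)c2cc(Cl)ccc2N1CN1CCN(c2ccc(Cl)cc2)CC1`: 268000 nM

Compound 1 stands highest of the three numbers in this assay; compound 2 lies closest to it, with a 1.2-fold lower number from compound 1 to compound 2 (0.09 log units; within the scatter), and compound 3 furthest, its value being the lowest of the set. Compound 4, `CCN(CC)CN1C(=O)/C(=N\NC(=S)NO)c2cc(F)ccc21`, differs from compound 1 in one place: fluoro in place of chloro on an aromatic carbon. For the measured compounds named here, no measured step touches this halogen swap; the only step on record, from compound 1 to compound 2 on an oxygen, stayed within the scatter. Nothing in the series therefore points to a move in either direction, and the expected step is a 1.1-fold lower number from compound 1 to compound 4 (0.05 log units; within the scatter). Compound 4 is estimated at 500000 nM in this assay, with a range from 250000 nM to 1000000 nM.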

Compound 4, half-maximal cytotoxic concentration: 521000 nM
Compound 4: middle estimate off by 1.0-fold (0.02 log units), on the low side; measured number inside the range.
By their numbers in this assay, from the lowest: compounds 3, 2, 4 and 1 (each within the scatter of the next, the first and the last beyond it).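

In this assay, fluoro in place of chloro gives a 1.1-fold lower number from compound 1 to compound 4 (0.03 log units; within the scatter) on this aromatic carbon, meta to a fused ring and para to a fused ring. For the compounds shown here, this is the first reading at this position, and it shows that the two halogens cannot be told apart here in this assay. No measurement is available that bears on why this is so.

Still open, as far as these compounds go, is whether a group other than a halogen at this carbon, such as methoxy, nitrile or an amine, would stay within the scatter. Also open, from the compounds shown here alone, is whether hydrogen there would do the same.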